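From a Cyclic Amine to a Carboxylic Acid Side Chain

The compounds below may be only part of what the source reports. "The series", "measured", "known", "first", "only" and "open" are said of these compounds alone.

For the measured compounds named here, compound 2 `N#CC1=C(NCN2CCCC2)N(c2ccccc2)C(=O)N2CCCCC(N3CCCC3)C12` gives 35.3% in a functional assay on the whole organism (strain albino) for inhibition, with Rattus norvegicus as the target, read by paw edema, with stated times of 1 h and 3 h, at a dose of 20 mmol/kg by the intraperitoneal route (a lower number here means a weaker effect, a higher number a stronger effect of the compound at the dose given), the lower of the two numbers known, while compound 1 `N#CC1=C(NCC(=O)N2CCOCC2)N(c2ccccc2)C(=O)N2CCCCC(N3CCCC3)C12` gives 73.5% in this assay. Going by the values given here, the only step measured, a number 38.2 percentage points lower from compound 1 to compound 2 (beyond the scatter), bears on compound 3 `N#CC1=C(NCC(=O)O)N(c2ccccc2)C(=O)N2CCCCC(N3CCCC3)C12`, whose change from compound 2 is carboxy in place of pyrrolidin-1-yl on a saturated chain carbon bound to an amine nitrogen. That earlier step removed a carbonyl-bearing group and lowered the reading sharply; compound 3 restores a carbonyl within the carboxy group, so a gain is expected, though it need not climb all the way back to compound 1. Compound 3 is expected to give 58%, within 38% to 78%, a step of a number 22.7 percentage points higher from compound 2 to compound 3 (beyond the scatter).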

Compound 3, a percentage reported as inhibition, in the whole organism at one dose (the size of the read-out at that dose, not a potency): 89.2%
Compound 3: middle estimate off by 31.2 percentage points, on the low side; the whole stated range lies below it.
By their numbers in this assay, from the lowest: compound 2; then compound 1; then compound 3.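

In this assay a free carboxy group on this saturated chain carbon carries the highest reading of the three, with a number 53.9 percentage points higher from compound 2 to compound 3 (beyond the scatter). Hydroxy in place of morpholin-4-yl on a carbonyl carbon gives a number 15.7 percentage points higher from compound 1 to compound 3 (beyond the scatter), so the morpholin-4-yl is not needed for a strong reading here. Nothing available explains either step.

Going by these compounds, whether a methyl ester, a primary amide or a longer chain ending in the carboxylic acid would hold this reading stays open. So does the effect of an open-chain amine in place of pyrrolidin-1-yl.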